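The compounds below may be only part of what the source reports. "The series", "measured", "known", "first", "only" and "open" are said of these compounds alone.

Measured so far:
- compound 1, `Cc1ccc(NS(=O)(=O)C2CCCCC2=O)c(C)c1`: 15.6%
- compound 2, `Cc1cc(F)ccc1NS(=O)(=O)C1CCCCC1=O`: 28.7%

Compound 1 stands at the lower of the two numbers in a functional assay on BGC-823 cells (Homo sapiens) for antiproliferative activity, read by sulforhodamine B assay, tested at 100 ug/mL; a higher number here means more inhibition at the concentration tested (going by the name of the read-out), a lower number less inhibition; the nearest measured neighbour is compound 2, and the step of a number 13.1 percentage points higher from compound 1 to compound 2 (beyond the scatter) is the only one recorded in the series. Compound 3, `Cc1ccc(NS(=O)(=O)C2CCCCC2=O)cc1`, has not yet been measured in this assay. It differs from compound 1 by hydrogen in place of methyl on an aromatic carbon. Going by the values given here, that change does not match the one measured step: the step from compound 1 to compound 2 swaps a methyl for a fluoro at a different aromatic carbon, whereas here a methyl is simply taken away. Among the compounds with values here, the one measured step, modest and beyond the scatter, shows that a single change on this ring can move the number, but offers no direction for loss of a methyl. Within the data shown here, with no bearing step, the expected step of a number 2.4 percentage points higher from compound 1 to compound 3 (within the scatter) is taken as none beyond the scatter. Among the measured compounds shown here, the estimate for compound 3 in this assay is therefore 18%, with a range from 5% to 35%, the width reflecting that a shift the size of the one measured step cannot be ruled out in either direction.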

Compound 3, a percentage reported as inhibition, at one concentration (the size of the read-out at that concentration, not a potency): 32.1%
Compound 3: middle estimate off by 14.1 percentage points, on the low side; measured number inside the range.
By their numbers in this assay, from the lowest: compound 1; then compounds 2 and 3 (each within the scatter of the next).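

Working notes on the methyl ortho to a large group: in this assay, hydrogen in place of this methyl gives a number 16.5 percentage points higher from compound 1 to compound 3 (beyond the scatter), the first reading at this position and the first for a methyl lost rather than exchanged for another group. The step lies beyond the scatter, so the number in this assay does not depend on keeping this methyl, and its presence goes with a lower inhibition in this pair. Compound 1 now lies beyond the scatter from both measured neighbours, so a change at either of these two aromatic carbons has given a higher number, though each carbon rests on one pair only, and no measurement at hand accounts for the step.

Open, going by these compounds, is whether a chlorine, a methoxy group or an amine on this same aromatic carbon would read like the hydrogen of compound 3 or like the methyl of compound 1. Also open is whether the two changes add up on one ring, as no pair among the compounds shown combines hydrogen at this carbon with fluoro at the other.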